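Swapping an Ethoxy for Aminoamino on a Carbonyl

The source may hold more compounds than are shown below. What is called first, only, known or untested is meant among the compounds shown, and "the series" means these compounds.

Of the compounds shown here, two have so far been measured in a physicochemical assay for inhibition, read by spectrophotometry, tested at 100 uM; on this read-out higher numbers stand for more inhibition at the one concentration tested (going by the name of the read-out) and lower numbers for less inhibition. Compound 1 `CCOC(=O)NC(c1ccccc1)c1ccc(Cl)cc1` gives 21% in this assay. Compound 2 `COc1cc(NC(C)CCCNC(=O)NNC(=O)NCCO)c2ncccc2c1`, built on a different core, gives 27% in this assay. The two numbers lie within the usual scatter of repeated measurements of this kind, so compound 1 cannot be set apart from compound 2; it simply sits alongside it. Among the measured compounds shown here, since these two compounds differ in many places at once, no step between measured compounds that differ in a single place is available to show how far one small edit moves the read-out.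

Compound 3 `NNC(=O)NC(c1ccccc1)c1ccc(Cl)cc1` has not yet been measured. It differs from compound 1 in one place: aminoamino in place of ethoxy on a carbonyl carbon. The core of compound 1 is left untouched. For the measured compounds named here, with no comparable step to draw on, the expectation rests on the modest size of the edit alone. The step of a number 4 percentage points higher from compound 1 to compound 3 (within the scatter) is expected to be small, not beyond the scatter in either direction. Compound 3 is therefore estimated at 25%, with a range from 5% to 50%.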

Compound 3, a percentage reported as inhibition, at one concentration (the size of the read-out at that concentration, not a potency): 52%
Estimate against measurement, compound 3: 27 percentage points below; the whole stated range lies below it.
By their numbers in this assay, from the lowest: compounds 1 and 2 (each within the scatter of the next); then compound 3.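

In this assay, aminoamino in place of ethoxy on a carbonyl carbon whose other neighbour is an amide-type nitrogen gives a number 31 percentage points higher from compound 1 to compound 3 (beyond the scatter), with the rest of the molecule left as it was. This shows that the read-out responds strongly to what sits at this one place, something the earlier pair could not show, since those compounds differ in many places at once. No measurement shown here accounts for the size of this step, so the ethoxy and aminoamino groups can be compared only by the result of this single swap.

From the compounds shown here alone, a single swap cannot separate the contribution of the ethoxy group leaving from that of the aminoamino group entering, so it remains open whether a plain amino group, a methylamino group or a hydroxyl group on the same carbonyl carbon would give a similar step. Going by these compounds, it also remains open whether the same exchange would move the read-out as far on a different core, or whether this large step belongs to the core of compound 1 alone.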